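The source may hold more compounds than are shown below. What is called first, only, known or untested is meant among the compounds shown, and "the series" means these compounds.

Working notes on the series. In a functional assay on MDA-MB-231 cells (Homo sapiens) for antiproliferative activity, read by MTT assay, with a stated time of 24 h (on this read-out higher numbers stand for weaker inhibition and lower numbers for stronger inhibition), compound 1 `O=C(NNc1ccccc1Cl)c1ccc(NS(=O)(=O)c2cnc(O)nc2O)cc1` gives 4010 nM. Compound 2 `Cc1ccccc1NNC(=O)c1cccc(NS(=O)(=O)c2cnc(O)nc2O)c1` gives > 20000 nM, which is a limit and not a number. Compound 2 therefore has no exact position, and the evidence so far reads: the limit of > 20000 nM in this assay, at which 1 of the 2 values shown sits.

Next is compound 3 `O=C(NNc1cccc(Cl)c1)c1cccc(NS(=O)(=O)c2cnc(O)nc2O)c1`, with 3-chlorophenyl in place of the 2-methylphenyl of compound 2 on an amine nitrogen: 3-chlorophenyl in place of 2-methylphenyl on an amine nitrogen. Among the compounds with values here, no step between measured compounds is available to size this change. Compound 1 at 4010 nM shows that a numerical reading is attainable in this assay, so a modest move towards stronger inhibition is expected. A second limit remains quite possible. The expected step is an at least 1.6-fold lower number from compound 2 to compound 3 (0.22 log units; that floor lies within the scatter), an estimate of uncertain size. For compound 3 the estimated value is 12000 nM, with an expected range of 4000 nM to 20000 nM.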

Compound 3, half-maximal inhibitory concentration: 7760 nM
Compound 3: middle estimate off by 1.5-fold (0.19 log units), on the high side, and the stated range covers the measured number.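

On an amine nitrogen whose other neighbours are an amide-type nitrogen, the aryl group matters: 3-chlorophenyl in place of 2-methylphenyl gives an at least 2.5-fold lower number from compound 2 to compound 3 (0.41 log units; beyond the scatter) in this assay. Of this pair, only compound 3 has a numerical reading, so the change brings the read-out within measurable range. Compound 2 has a limit and not a number, which leaves the full size of the step open: the limit of > 20000 nM in this assay, at which 1 of the 3 values shown sits.

The change replaces methyl with chlorine and also alters the substituent's place on the phenyl ring, so this pair cannot separate the contribution of the substituent from that of its place. As far as these compounds go, whether a methoxy group, an amine or a carboxylic acid on this phenyl ring would keep a numerical reading remains open.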